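A few compounds are considered here, and "the series" means these few. Any claim that something is new, unique, unknown or untested is made for them only; others in the source may bear on it.

Three compounds sharing an amidine end were tested in a functional assay on SN12C cells (Homo sapiens) for inhibition, read by sulforhodamine B assay, with a stated time of 48 h; a lower number here means a stronger inhibitor of growth, a higher number a weaker inhibitor of growth. Compound 1 `COc1ccc(-c2ccc(-c3ccc(C(=N)N)o3)o2)cc1` gives 2020 nM in this assay. Compound 2 `N=C(N)c1ccc(-c2ccc(-c3ccc(Cl)cc3)s2)s1` gives 1910 nM in this assay, and compound 3 `N=C(N)c1ccc(-c2ccc(-c3cncc4ccccc34)s2)s1` gives 1800 nM. The number for compound 1 is the highest of the three, yet each of the other two lies within the usual scatter of it, so the three cannot be ranked. Compound 4 `N=C(N)c1ccc(-c2ccc(-c3ccccc3)o2)o1` has not yet been measured in this assay. It differs from compound 1 in one place: hydrogen in place of methoxy on an aromatic carbon. Within the data shown here, no measured pair shows this change. Because compound 1 gives 2020 nM and compounds 2 and 3 sit within the scatter of that, the step is expected to stay within the scatter as well: a 1.1-fold higher number from compound 1 to compound 4 (0.04 log units; within the scatter). Compound 4 is therefore estimated at 2200 nM, between 900 nM and 5500 nM.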

Compound 4, concentration for 50% growth inhibition: 3120 nM
Beside the measured number, compound 4's estimate is 1.4-fold (0.15 log units) below it; the range from low to high includes it.
By their numbers in this assay, from the lowest: compounds 3, 2, 1 and 4 (each within the scatter of the next).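

In this assay, hydrogen in place of methoxy on an aromatic carbon, para to a large group, gives a 1.5-fold higher number from compound 1 to compound 4 (0.19 log units; within the scatter). Among these compounds, this is the first direct test of a single change in this set, and it shows that methoxy at this position can be lost without a clear change in the number. Nothing measured here explains the size of this step.

Going by these compounds, whether an amine, a carboxylic acid or a longer chain at this position would move the number further remains open. So does whether the same change would behave alike on a different core.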